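Swapping one oxazole for its isomer: a lipophilicity estimate

This account rests on a few compounds, and the source may have more. Where it says the series, first, only, none or still open, it means among the compounds named here.

Values measured so far in a physicochemical assay for lipophilicity, using the shake flask method, in phosphate buffer, measured as octanol-water partition, at pH 7.4; a lower number here means a more polar compound, a higher number a more lipophilic compound:
- Compound 1 (`Cc1noc(CNC(=O)c2ccc(C)c(S(=O)(=O)Nc3ccc(-c4cnco4)cc3)c2)n1`): 2.2
- Compound 2 (`COc1ccc(C(=O)NC(C)c2cnn(C)n2)cc1S(=O)(=O)Nc1ccc(Cl)cc1`): 2.6; 2.7 (2 entries)
- Compound 3 (`COc1ccc(C(=O)NCc2nc(C)no2)cc1S(=O)(=O)Nc1ccc(C)cc1`): 2.3

Compound 1 (2.2) and compound 3 (2.3) lie within the usual scatter of each other. Compound 2 has two entries rather than a single number (the several entries of compound 2 in this assay, 2.6; 2.7 (2 entries)), and these give an idea of how closely repeat measurements agree.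

Compound 4 (`Cc1noc(CNC(=O)c2ccc(C)c(S(=O)(=O)Nc3ccc(-c4ccno4)cc3)c2)n1`) differs from compound 1 in a single place (1,2-oxazol-5-yl in place of 1,3-oxazol-5-yl on an aromatic carbon): it carries 1,2-oxazol-5-yl in place of 1,3-oxazol-5-yl on an aromatic carbon. The two compounds have the same atoms, joined differently. Among the compounds with values here, no measured pair shows this swap, so the best anchor is compound 1 itself (2.2). In this assay, a step no larger than the usual scatter is expected, with no firm direction (a number 0.10 log units higher from compound 1 to compound 4 (within the scatter)). The estimated value for compound 4 is 2.3 (expected range 2 to 2.7).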

Compound 4, distribution coefficient: 2.3
Beside the measured number, compound 4's estimate shows no gap at the digits printed, and the stated range covers the measured number.
By their numbers in this assay, from the lowest: compounds 1, 3 and 4 (each within the scatter of the next).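

In this assay, exchanging 1,3-oxazol-5-yl for 1,2-oxazol-5-yl, on an aromatic carbon para to a large group, gives a number 0.10 log units higher from compound 1 to compound 4 (within the scatter). This is the first pair shown that differs in one place, so it is the first direct reading at this position, and it concerns two groups with the same atoms, joined differently. The step cannot be told apart from the agreement between repeat measurements, which can be judged from a single example: the several entries of compound 2 in this assay, 2.6; 2.7 (2 entries)

The compounds shown leave open how a group of another kind at this place, such as an amine or a carboxylic acid, would read in this assay. They also leave open whether the same swap would give a similar step on a core other than that of compound 1.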